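Nitro in Place of Methylsulfanyl on a Chalcone-Type Scaffold

The source may report more compounds than this note shows. Statements on the series, on what has been measured and on what is new or still open speak of the compounds shown alone.

Of the compounds shown here, two have been measured so far in a functional assay on A549 cells (Homo sapiens) for antiproliferative activity, read by MTT assay, with a stated time of 48 h; on this read-out lower numbers stand for stronger inhibition and higher numbers for weaker inhibition. Compound 1 `COc1cc(C(=O)/C=C/c2cn(C)c3ccccc23)cc(SC)c1OC` gives 188 nM in this assay, the highest of the two numbers. Compound 2 `COc1ccc2c(/C=C(\C)C(=O)c3cc(OC)c(OC)c([Se]C)c3)c[nH]c2c1` gives 8 nM in this assay, a much lower number than compound 1, but these two compounds differ in several places at once, so this pair alone says nothing about any single change.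

The next compound, compound 3 `COc1cc(C(=O)/C=C/c2cn(C)c3ccccc23)cc([N+](=O)[O-])c1OC`, has not yet been measured. It differs from compound 1 in one place: nitro in place of methylsulfanyl on an aromatic carbon. Going by the values given here, no measured pair shows what this change does in this assay, so the expectation rests on compound 1 alone. A modest step toward a higher number, possibly still within the scatter, is expected a 1.6-fold higher number from compound 1 to compound 3 (0.20 log units; within the scatter). For compound 3 the estimate in this assay is 300 nM, with a likely range from 100 nM to 1000 nM.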

Compound 3, half-maximal inhibitory concentration: 1060 nM
Compound 3: middle estimate off by 3.5-fold (0.55 log units), on the low side; the whole stated range lies below it.
By their numbers in this assay, from the lowest: compound 2; then compound 1; then compound 3.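

Going by these compounds alone, putting nitro in place of methylsulfanyl on this aromatic carbon gives a 5.6-fold higher number from compound 1 to compound 3 (0.75 log units; beyond the scatter) in this assay and is the first single change here whose effect can be read. With the rest of the molecule held the same, the group on this carbon alone moves the number beyond the usual scatter, toward weaker inhibition, so this position is not indifferent to what it carries. Nothing measured on these compounds accounts for this step.

Still open, on these data alone, is whether this weakening belongs to nitro in particular or would also follow from another group on the same carbon, such as an amine, a chlorine atom or a longer chain like ethylsulfanyl. Also open, as far as these compounds go, is whether the same change would give a step of similar size on a different core, such as that of compound 2.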